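Changing one side chain on a shared core

The source may hold more compounds than are shown below. What is called first, only, known or untested is meant among the compounds shown, and "the series" means these compounds.

- compound 1 `C=C1CC[C@@H](C(=O)C(C)C)[C@H]2[C@@]1(C)[C@@H](O)C(=O)C(=C)[C@]2(C)C[C@@H](OC(=O)/C(C)=C/C)[C@]1(O)COC(=O)C1` gives 9.04 ug/mL
- compound 2 `C=C1CC[C@@H](C(=O)/C(C)=C/C)[C@H]2[C@@]1(C)[C@@H](O)C(=O)C(=C)[C@]2(C)C[C@@H](OC(=O)/C(C)=C/C)[C@]1(O)COC(=O)C1` gives 16.2 ug/mL

Within the data shown here, in a functional assay on cells (Drosophila melanogaster) for cytotoxicity (on this read-out lower numbers stand for stronger inhibition and higher numbers for weaker inhibition), compound 2 cannot be told apart from compound 1, the only other compound measured (a 1.8-fold higher number from compound 1 to compound 2 (0.25 log units; within the scatter)). Among the measured compounds shown here, that single step, 1-methylprop-1-en-1-yl in place of isopropyl on a carbonyl carbon, is the only evidence that bears on the next change. Compound 3 `C=C1CC[C@@H](C(=O)C(C)CC)[C@H]2[C@@]1(C)[C@@H](O)C(=O)C(=C)[C@]2(C)C[C@@H](OC(=O)/C(C)=C/C)[C@]1(O)COC(=O)C1` alters the same spot, with sec-butyl in place of 1-methylprop-1-en-1-yl on a carbonyl carbon. With so small a step as the guide, no change beyond the scatter is expected in this assay (a 1.4-fold lower number from compound 2 to compound 3 (0.13 log units; within the scatter)). The estimate for compound 3 is 12 ug/mL (expected range 6.5 ug/mL to 22 ug/mL).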

Compound 3, half-maximal inhibitory concentration: 8.3 ug/mL
For compound 3 the middle estimate is 1.4-fold (0.16 log units) above the measured one, and the stated range covers the measured number.
By their numbers in this assay, from the lowest: compounds 3, 1 and 2 (each within the scatter of the next).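

Swapping 1-methylprop-1-en-1-yl for sec-butyl on this carbonyl carbon removes the side chain's double bond, yet in this assay the result stays inside the scatter (a 2.0-fold lower number from compound 2 to compound 3 (0.29 log units; within the scatter)). Methyl in place of hydrogen on the saturated chain also gives no readable change (a 1.1-fold lower number from compound 1 to compound 3 (0.04 log units; within the scatter)). Compounds 1, 2 and 3 therefore cannot be told apart, and no supporting measurement explains this. As far as these compounds go, whether a much longer chain, an amine or a carboxylic acid at this carbonyl carbon would shift the number remains open.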